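Chloro to methyl on the aryl amine of compound 2

The source may hold more compounds than are shown below. What is called first, only, known or untested is meant among the compounds shown, and "the series" means these compounds.

Measured compounds:
compound 1, `CCCN(CC1CC1)C(=O)c1sc(Nc2c(Cl)cc(Cl)cc2Cl)nc1C`, 360 nM;
compound 2, `CCCN(Cc1sc(Nc2c(C)cc(Cl)cc2Cl)nc1C(F)(F)F)CC1CC1`, 16 nM.

Of the compounds shown here, two have been measured in an assay for displacement of a labelled ligand from corticotropin-releasing factor receptor 1 (Homo sapiens); a higher number here means a weaker inhibitor, a lower number a stronger inhibitor. Compound 2 gives 16 nM, the lowest of the two numbers, and compound 1 gives 360 nM, a value that lies well beyond the usual scatter above it. Going by the values given here, the two compounds differ in several places at once, so no single step between them can be drawn; their values show only that compound 2 is the stronger inhibitor of the pair.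

Compound 3, `CCCN(Cc1sc(Nc2c(C)cc(C)cc2Cl)nc1C(F)(F)F)CC1CC1`, is derived from compound 2 by one change: methyl in place of chloro on an aromatic carbon, which turns the 2,4-dichloro-6-methylphenyl group into a 2-chloro-4,6-dimethylphenyl group. Among the compounds with values here, no measured pair in this set isolates such an exchange, so the size of the effect is uncertain. The author expects a step from compound 2 to compound 3 of a 1.6-fold higher number from compound 2 to compound 3 (0.19 log units; within the scatter), within or near the scatter. Compound 3 is estimated at 25 nM, with a likely range of 8 nM to 80 nM.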

Compound 3, inhibition constant: 23 nM
Beside the measured number, compound 3's estimate is 1.1-fold (0.04 log units) above it; the range from low to high includes it.
By their numbers in this assay, from the lowest: compounds 2 and 3 (each within the scatter of the next); then compound 1.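

In this assay, methyl in place of chloro at this position, para to a large group, gives a 1.4-fold higher number from compound 2 to compound 3 (0.16 log units; within the scatter) and so leaves the two compounds indistinguishable. Going by these compounds alone, this is the first comparison in the set that isolates one place, and it shows that the 2,4-dichloro-6-methylphenyl and 2-chloro-4,6-dimethylphenyl groups cannot be told apart in this measurement. Nothing available explains this outcome.

The compounds shown leave open whether a methoxy group, an amine or a longer chain at this position would read the same, and whether the same exchange at the remaining chloro group would do so. Compound 1 still differs from compound 2 and compound 3 in several places, so what separates it from them cannot be assigned to any single group.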